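Replacing the Side Chain of Compound 1

The source may hold more compounds than are shown below. What is called first, only, known or untested is meant among the compounds shown, and "the series" means these compounds.

In a functional assay on MCF7 cells (Homo sapiens) for antiproliferative activity, read by CCK-8 assay, with a stated time of 48 h (a higher number here means a weaker inhibitor, a lower number a stronger inhibitor), compound 1 (`C=C(C)C(=O)NCCOc1ccc(Oc2c(-c3ccc(F)cc3)sc3cc(O)ccc23)cc1`) gives > 25000 nM, which is a limit of the assay and not a number. Compound 1 therefore stands at the limit of > 25000 nM in this assay, at which 1 of the 2 values shown sits. Going by the values given here, the only true number so far belongs to compound 2 (`O=C(/C=C/CN1CC(Oc2ccc(Oc3c(-c4ccc(F)cc4)sc4cc(O)ccc34)cc2)C1)N1CCCC1`), which gives 8450 nM.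

The next compound to be tested is compound 3 (`O=C(/C=C/CNCCOc1ccc(Oc2c(-c3ccc(F)cc3)sc3cc(O)ccc23)cc1)N1CCC1`). Here 3-((azetidin-1-yl)carbonyl)prop-2-en-1-yl takes the place of (1-methylethenyl)carbonyl on an amine nitrogen, a change counted as 3-((azetidin-1-yl)carbonyl)prop-2-en-1-yl in place of (1-methylethenyl)carbonyl on an amine nitrogen. The rest of the molecule stays the same.

Among the compounds with values here, no measured pair shows what this exchange does, so any forecast is loose. Since compound 1 gives > 25000 nM, there is little room for a weaker result that still yields a number. The measured value of compound 2 at 8450 nM suggests the level a number might take in this assay. A moderate gain in strength is expected, with an estimated change of an at least 3.1-fold lower number from compound 1 to compound 3 (0.49 log units; beyond the scatter). For compound 3 the estimate is 8000 nM, with an expected range from 2500 nM to 25000 nM.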

Compound 3, half-maximal inhibitory concentration: 7340 nM
The estimate for compound 3 lay 1.1-fold (0.04 log units) above the measured number; measured number inside the range.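

In this assay compound 1 gives > 25000 nM, which is a limit of the assay and not a number. Putting 3-((azetidin-1-yl)carbonyl)prop-2-en-1-yl in place of (1-methylethenyl)carbonyl on the amine nitrogen gives an at least 3.4-fold lower number from compound 1 to compound 3 (0.53 log units; beyond the scatter), so this position accepts the larger group, with its four-membered ring, and the change brings a true number within reach. How large the step really is cannot be read, because only one end of it is a number: the limit of > 25000 nM in this assay, at which 1 of the 3 values shown sits.

The entering group differs from the leaving one in several ways at once, so the compounds shown do not say whether the azetidine ring, the longer chain or the change at the amine nitrogen carries the step. Also open, on these data alone, is how a dimethylamino group in place of the azetidine ring, or a saturated chain in place of the prop-2-en-1-yl link, would read in this assay.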